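From a hydroxy group to a longer side chain

The source may report more compounds than this note shows. Statements on the series, on what has been measured and on what is new or still open speak of the compounds shown alone.

Measured in an ADME assay on MT4 cells (Homo sapiens) for cytotoxicity, read by MTT assay, with a stated time of 96 h; on this read-out lower numbers stand for higher toxicity in this test and higher numbers for lower toxicity in this test:
compound 1 `Oc1ccc(-c2nc3cc(C(F)(F)F)ccc3[nH]2)cc1`: 17000 nM
compound 2 `COc1ccc(-c2nc3cc(Cl)c(Cl)cc3[nH]2)c([N+](=O)[O-])c1`: 2000 nM

For the measured compounds named here, of the two numbers known so far, compound 1 stands highest at 17000 nM, while compound 2 lies lower at 2000 nM, a gap beyond the usual scatter. Compound 3 `O=C(O)CCC(=O)Nc1ccc(-c2nc3cc(C(F)(F)F)ccc3[nH]2)cc1` keeps the core of compound 1 but carries ((2-carboxyethyl)carbonyl)amino in place of hydroxy on an aromatic carbon, para to a large group (((2-carboxyethyl)carbonyl)amino in place of hydroxy on an aromatic carbon). Going by the values given here, no measured pair shows this change, so the expectation rests only on compound 1 at 17000 nM and on the structural change itself. A modest upward step is expected in this assay, toward lower toxicity in this test. The estimated step is a 2.4-fold higher number from compound 1 to compound 3 (0.37 log units; beyond the scatter). For compound 3 the expected value is 40000 nM, with an estimated range of 12000 nM to 120000 nM.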

Compound 3, half-maximal cytotoxic concentration: > 100000 nM
Compound 3: a limit, no number (the forecaster's own chance of this, stated with the estimate: 35%); middle value at least 2.5-fold (0.39 log units) away from the limit.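

In this assay compound 3 gives > 100000 nM, which is a limit of the assay and not a number: the limit of > 100000 nM in this assay, at which 1 of the 3 values shown sits.

As far as these compounds go, putting ((2-carboxyethyl)carbonyl)amino in place of hydroxy on an aromatic carbon, para to a large group, brings an at least 5.8-fold higher number from compound 1 to compound 3 (0.76 log units; beyond the scatter), and how far the step extends past this stays unknown. This one pair shows that, on the core of compound 1, the longer chain at this position raises the number rather than lowering it, toward lower toxicity in this test.

A single pair cannot tell whether the step belongs to the amide link, to the carboxylic acid or to the length of the chain. A plain amine, a methyl ester of the acid or a shorter amide without the acid at this position would bear on that question.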